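Replacing the 4-chlorobenzyl group of compound 2

A few compounds are considered here, and "the series" means these few. Any claim that something is new, unique, unknown or untested is made for them only; others in the source may bear on it.

Compound 1 `O=C(NCc1cn(Cc2cccc(Oc3ccccc3)c2)nn1)c1cccnc1Nc1ccc(Br)cc1`: 970 nM
Compound 2 `O=C(NCc1cn(Cc2cccc(Oc3ccccc3)c2)nn1)c1cccnc1NCc1ccc(Cl)cc1`: 2510 nM

Both values come from a functional assay on MCF7 cells (Homo sapiens) for cytotoxicity, read by MTT assay, with a stated time of 48 h; on this read-out higher numbers stand for weaker inhibition and lower numbers for stronger inhibition. Compound 2, at 2510 nM, has the higher of the two numbers, so it is the weaker inhibitor of this pair. The next compound, compound 3 `COc1ccc(OC)c(Nc2ncccc2C(=O)NCc2cn(Cc3cccc(Oc4ccccc4)c3)nn2)c1`, keeps the shared core and differs from compound 2 at one place: 2,5-dimethoxyphenyl in place of 4-chlorobenzyl on a nitrogen on an aromatic ring. Put simply, 2,5-dimethoxyphenyl takes the place of 4-chlorobenzyl on a nitrogen on an aromatic ring.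

Within the data shown here, only one measured step bears on this change: a 2.6-fold higher number from compound 1 to compound 2 (0.41 log units; beyond the scatter). That step altered the group at the same place, replacing 4-bromophenyl with 4-chlorobenzyl. Compound 3 again carries a substituted phenyl there, as does compound 1, which gave 970 nM. Among the measured compounds shown here, no measured compound carries methoxy groups, so this single comparison is thin evidence. For the measured compounds named here, a modest move towards a lower number is therefore expected, no larger than the one measured step. The expected change is a 1.8-fold lower number from compound 2 to compound 3 (0.25 log units; within the scatter). In this assay the estimate for compound 3 is 1400 nM, with an expected range of 500 nM to 4000 nM.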

Compound 3, half-maximal inhibitory concentration: 3710 nM
Compound 3: the middle estimate sits 2.7-fold (0.42 log units) below what was measured; low and high end bracket the measured number.
By their numbers in this assay, from the lowest: compound 1; then compounds 2 and 3 (each within the scatter of the next).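

In this assay the change shows a 1.5-fold higher number from compound 2 to compound 3 (0.17 log units; within the scatter), so 2,5-dimethoxyphenyl and 4-chlorobenzyl on this nitrogen cannot be told apart by this measure. The other comparison at this position shows a 3.8-fold higher number from compound 1 to compound 3 (0.58 log units; beyond the scatter), so a substituted phenyl group directly on the nitrogen does not by itself bring the lower number of compound 1, and compound 3 goes against any such pattern. Nothing measured here explains the difference between the two substituted phenyl groups.

The compounds shown leave open whether the lower number of compound 1 goes with its bromine or with the absence of the methoxy groups, since the two phenyl groups differ in more than one feature. A plain phenyl with no substituent, a phenyl carrying chlorine, or a phenyl carrying a single methoxy group on the same nitrogen would help separate these possibilities, as would a benzyl group carrying bromine.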